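This account rests on a few compounds, and the source may have more. Where it says the series, first, only, none or still open, it means among the compounds named here.

Compound 1, whose structure is `O=C(NCCCCC(c1ccc(F)cc1)c1ccc(F)cc1)Nc1ccc(Cl)cc1`, is one of three compounds that share the same core and were tested in a functional assay on MDA-MB-231 cells (Homo sapiens) for cytotoxicity, read by MTT assay, with a stated time of 48 h; a lower number here means a stronger inhibitor, a higher number a weaker inhibitor. Compound 1 gives 7680 nM there, the highest number of the three. Compound 2, with structure `Fc1ccc(C(CCCCNC(=S)Nc2ccc(Cl)c(C(F)(F)F)c2)c2ccc(F)cc2)cc1`, gives 3660 nM, a number beyond the scatter of compound 1. Compound 3, with structure `O=C(Nc1ccc(Cl)c(C(F)(F)F)c1)OCCCCC(c1ccc(F)cc1)c1ccc(F)cc1`, gives 4580 nM, which lies within the scatter of compound 1.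

The next compound, compound 4, has the structure `O=C(NCCCCC(c1ccc(F)cc1)c1ccc(F)cc1)c1ccc(Cl)c(C(F)(F)F)c1` and has not yet been measured. It differs from compound 1 in one place: 4-chloro-3-(trifluoromethyl)phenyl in place of (4-chlorophenyl)amino on a carbonyl carbon. The group that enters is the same one that appears in compound 2 and compound 3.

Among the compounds with values here, no measured pair shows this exact change, so the step can only be expected, not read off. A modest downward step of a 1.8-fold lower number from compound 1 to compound 4 (0.26 log units; within the scatter) is expected, because compound 2 gives 3660 nM and compound 3 gives 4580 nM with that group in place. For compound 4 the estimated value is 4200 nM, within a range from 1500 nM to 11000 nM.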

Compound 4, half-maximal inhibitory concentration: 11700 nM
For compound 4 the middle estimate is 2.8-fold (0.44 log units) below the measured one; the measured number lies above the stated range.
By their numbers in this assay, from the lowest: compounds 2, 3, 1 and 4 (each within the scatter of the next, the first and the last beyond it).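

Within the data shown here, this is the first step in one place that can be read in this assay: there is a 1.5-fold higher number from compound 1 to compound 4 (0.18 log units; within the scatter) when 4-chloro-3-(trifluoromethyl)phenyl replaces (4-chlorophenyl)amino on a carbonyl carbon. At this position, then, the group that leaves can give way to a larger one with no hydrogen-bond donor, and the number stays within the usual scatter. Nothing available explains the size of this step.

Going by these compounds, this single step swaps the nitrogen and adds the trifluoromethyl group together, so the share of each remains unknown. On these data alone, it also remains open how the number would respond to an amine or a carboxylic acid on this carbonyl carbon, or to a longer chain in the shared core.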